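Methoxy removal at the biaryl terminus of compound 3

The source may report more compounds than this note shows. Statements on the series, on what has been measured and on what is new or still open speak of the compounds shown alone.

Compound 3 `COc1ccc(-c2ccc(CN(CCC3CCN(Cc4ccc(C)cc4)CC3)C(=O)NC(C)C)cc2)cc1` gives 467 nM in an in vitro functional assay on HEK293 cells for antagonist activity at melanin-concentrating hormone receptor 1 (Homo sapiens), read by GTPgammaS binding, with a stated time of 45 min (on this read-out higher numbers stand for weaker inhibition and lower numbers for stronger inhibition), the higher of the two numbers in hand, though compound 1 `Cc1ccc(CN2CCC(NC(=O)NCc3ccc(-c4cccc(C#N)c4)cc3)CC2)cc1` with 411 nM sits within the scatter of it. Compound 2 `COc1ccc(-c2ccc(CN(CC(=O)C(C)(C)O)C(=O)NC3CCN(Cc4ccc(C)cc4)CC3)cc2)cc1` reports only a limit in this assay, > 10000 nM; with the limit of > 10000 nM in this assay, at which 1 of the 3 values shown sits, it adds no number to compare. Compound 4 `Cc1ccc(CN2CCC(CCN(Cc3ccc(-c4ccccc4)cc3)C(=O)NC(C)C)CC2)cc1` differs from compound 3 by hydrogen in place of methoxy on an aromatic carbon of a six-membered aromatic ring of carbon only. Among the compounds with values here, no measured pair in this set isolates that change, so the expectation is a step of modest size towards weaker inhibition, or none beyond the scatter, a 1.6-fold higher number from compound 3 to compound 4 (0.21 log units; within the scatter). Compound 4 is therefore estimated at 750 nM, in the range 250 nM to 2500 nM.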

Compound 4, antagonist equilibrium constant: 220 nM
For compound 4 the middle estimate is 3.4-fold (0.53 log units) above the measured one; the whole stated range lies above it.
By their numbers in this assay, from the lowest: compounds 4, 1 and 3 (each within the scatter of the next, the first and the last beyond it). At a limit, above all of these: compound 2.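

In this assay, within the data shown here, the change from 4-methoxyphenyl to phenyl gives a 2.1-fold lower number from compound 3 to compound 4 (0.33 log units; beyond the scatter) and is the first single-place step. The methoxy, para to a large group, is thus not required for inhibition on this core, and its loss brings a modest gain. No measured property in hand accounts for this step.

Open, on these data alone, is how a chlorine, a hydroxyl, an amine or a longer ether such as ethoxy would read at this aromatic carbon. Also open, as far as these compounds go, is whether the same change keeps its direction on the core of compound 1.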